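Swapping the tetrazole substituent in a thiazole hydrazone series

The compounds below may be only part of what the source reports. "The series", "measured", "known", "first", "only" and "open" are said of these compounds alone.

Measured compounds:
- compound 1 `Cc1ccc(-c2cs/c(=N/NC(=O)CSc3nnnn3-c3ccccc3)n2-c2ccccc2)cc1` gives 14.7 ug/mL
- compound 2 `O=C(CSc1nnnn1-c1ccccc1)N/N=c1/scc(-c2ccc(F)cc2)n1-c1ccccc1` gives 24.3 ug/mL
- compound 3 `O=C(CSc1nnnn1-c1ccccc1)N/N=c1/scc(-c2ccc(Br)cc2)n1-c1ccccc1` gives 21 ug/mL

These three compounds were tested in a functional assay on C6 cells (Rattus norvegicus) for cytotoxicity, read by MTT assay, with a stated time of 24 h; on this read-out higher numbers stand for weaker inhibition and lower numbers for stronger inhibition. They share one core and differ only in the group on the outer aromatic ring. Compound 1 carries a methyl there and gives the lowest of the three numbers, yet its neighbours sit close: the step of a 1.7-fold higher number from compound 1 to compound 2 (0.22 log units; within the scatter) and the step of a 1.4-fold higher number from compound 1 to compound 3 (0.15 log units; within the scatter) both stay within the scatter, as does a 1.2-fold lower number from compound 2 to compound 3 (0.06 log units; within the scatter). So far, then, nothing in this set moves the read-out beyond what repeated measurement would give.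

Compound 4 `Cc1ccc(-c2cs/c(=N/NC(=O)CSc3nnnn3C)n2-c2ccccc2)cc1` is the unmeasured compound. Its change from compound 1 is methyl in place of phenyl on an aromatic nitrogen, placed on an aromatic nitrogen of a five-membered aromatic ring with 4 nitrogen. For the measured compounds named here, none of the measured steps touches this part of the molecule; they all concern the outer aromatic ring, so they say little about how this swap will read out. Without a bearing step, the expectation for compound 4 is a number near compound 1, with a step of a 1.2-fold higher number from compound 1 to compound 4 (0.09 log units; within the scatter) that is estimated to stay within the scatter. The estimate for compound 4 is therefore 18 ug/mL, with a range from 7 ug/mL to 45 ug/mL.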

Compound 4, half-maximal inhibitory concentration: 36.3 ug/mL
Compound 4: middle estimate off by 2.0-fold (0.30 log units), on the low side, within the range that was stated.
By their numbers in this assay, from the lowest: compounds 1, 3, 2 and 4 (each within the scatter of the next, the first and the last beyond it).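

In this assay, the substituent on the tetrazole nitrogen proves to be a place where a change can be read: methyl in place of phenyl gives a 2.5-fold higher number from compound 1 to compound 4 (0.39 log units; beyond the scatter), a modest step, but the only one in this set that is printed as beyond the scatter. Replacing the phenyl ring with a methyl therefore weakens inhibition in this one matched pair, whereas the swaps among methyl, fluoro and bromo on the outer aromatic ring could not be told apart from repeat measurement. No supporting data are available to explain this difference, so the result stands as an observation and not as an explained effect.

On these data alone, with only phenyl and methyl to compare at this nitrogen, it remains open whether an ethyl group, a benzyl group or a longer carbon chain would give a number closer to that of compound 1 or compound 4. As far as these compounds go, it is also open whether a phenyl ring bearing a methoxy group or an amine here would keep, improve or lose the result seen with the plain phenyl.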